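Shortening the amine side chain of a benzamide

This account rests on a few compounds, and the source may have more. Where it says the series, first, only, none or still open, it means among the compounds named here.

Compound 1 `COc1cc(N)c(Cl)cc1NC(=O)C1CCN(C/C=C/c2ccccc2)CC1` and compound 2 `CCCCCN1CCC(C(=O)Nc2cc(Cl)c(N)cc2OC)CC1` share one core and differ only in the chain on the ring amine. In a functional assay on the whole organism for antagonist activity, with Mus musculus as the target (a higher number here means that more compound is needed for the effect, a lower number that less compound is needed), compound 1 gives > 10 mg/kg, which is a limit of the assay rather than a number. In this assay compound 2 gives > 10 mg/kg, again only a limit. The step that the two limits leave unreadable from compound 1 to compound 2 therefore has no readable size, and both values sit at the limit of > 10 mg/kg in this assay, at which 2 of the 2 values shown sit. Compound 3 `CCN1CCC(C(=O)Nc2cc(Cl)c(N)cc2OC)CC1` has not yet been measured; it differs from compound 1 in one place: methyl in place of 2-phenylethenyl on a saturated chain carbon bound to an amine nitrogen in a ring. For the measured compounds named here, the one measured step that touches this place shows no size, so no direction beyond the scatter can be expected from it. For compound 3 a value of 15 mg/kg is expected, with a range from 5 mg/kg to 50 mg/kg, and most likely the assay will again report only a limit. This estimate amounts to an expected step that the limit leaves unreadable from compound 1 to compound 3.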

Compound 3, dose for half-maximal effect: > 10 mg/kg
Compound 3: no number, only a limit; the forecaster's own chance of this, stated with the estimate: 75%; the middle value lies beyond the limit too.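

In this assay compound 3 gives > 10 mg/kg as a limit and not a number, so the steps among compound 1, compound 2 and compound 3 cannot be read: the limit of > 10 mg/kg in this assay, at which 3 of the 3 values shown sit. The compounds shown leave open how far each lies past this limit, and whether any chain on the ring amine gives a readable dose.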